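A few compounds are considered here, and "the series" means these few. Any claim that something is new, unique, unknown or untested is made for them only; others in the source may bear on it.

Compound 1 `Cc1ccc2c(C3CCN(CCN4CCNC4=O)CC3)cn(-c3ccc(F)cc3)c2c1` and compound 2 `O=C1NCCN1CCN1CCC(c2cn(-c3ccc(F)cc3)c3cc(C(F)(F)F)ccc23)CC1` share one core and differ at a single aromatic carbon. In an assay on cell membranes for displacement of a labelled ligand from Adrenergic receptor alpha-1 (Rattus norvegicus) (on this read-out lower numbers stand for stronger inhibition and higher numbers for weaker inhibition), compound 1 gives 24 nM. Compound 2 gives 33 nM in this assay. The step of a 1.4-fold higher number from compound 1 to compound 2 (0.14 log units; within the scatter), trifluoromethyl in place of methyl on an aromatic carbon, does not separate the two. Among the two numbers in hand compound 1 stands lowest, with compound 2 nearest.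

Compound 3 `Cc1ccc2c(C3CCN(CCNC(=O)N(C)C)CC3)cn(-c3ccc(F)cc3)c2c1` keeps the core and the piperidine-linked chain of compound 1 and carries the change (dimethylcarbamoyl)amino in place of 2-oxoimidazolidin-1-yl on a saturated chain carbon, two bonds along the chain from an amine nitrogen in a ring: the cyclic urea is cut open to an acyclic dimethyl urea while the heavy-atom count, the donor count and the acceptor count stay equal. Going by the values given here, no measured step touches this part of the molecule; the single step shown sits on the aromatic ring and gives no guide to what happens two bonds along the chain from the ring amine nitrogen. The expectation therefore rests on compound 1 alone, and the step of a 1.7-fold higher number from compound 1 to compound 3 (0.22 log units; within the scatter) is estimated as small, with a wide range. Compound 3 is expected at 40 nM in this assay, between 12 nM and 130 nM.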

Compound 3, half-maximal inhibitory concentration: 22 nM
Compound 3: middle estimate off by 1.8-fold (0.26 log units), on the high side, within the range that was stated.
By their numbers in this assay, from the lowest: compounds 3, 1 and 2 (each within the scatter of the next).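

In this assay, the first step read at this position, on a saturated chain carbon, two bonds along the chain from an amine nitrogen in a ring, stays within the scatter (a 1.1-fold lower number from compound 1 to compound 3 (0.04 log units; within the scatter)). In this pair the ring of 2-oxoimidazolidin-1-yl is therefore not needed to keep the number in this range: the open (dimethylcarbamoyl)amino group, with the same counts of heavy atoms, donors and acceptors, reads alike. Nothing on hand accounts for the two ureas reading alike.

What remains open is whether the urea itself is needed at this place, since only two ureas are shown here; an acetamide, a sulfonamide or a primary amine in place of (dimethylcarbamoyl)amino would address that, and a longer chain in place of the ethyl of 2-((dimethylcarbamoyl)amino)ethyl would show how far the group's distance from the ring amine nitrogen matters. Going by these compounds, it is also open whether the open urea and the trifluoromethyl group, each of which has been read only on its own, would read alike when carried together on the shared core.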